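The compounds below may be only part of what the source reports. "The series", "measured", "known", "first", "only" and "open" are said of these compounds alone.

Measured so far:
compound 1, `CCCCCCCCCCCCCC[C@H](OCOC)[C@H](CN(CCCC)CCCC)NC(=O)OC(C)(C)C` — in a functional assay on NCI-H358 cells (Homo sapiens) for antiproliferative activity, read by sulforhodamine B assay, with a stated time of 48 h, tested at 10 uM (on this read-out higher numbers stand for more inhibition at the one concentration tested (going by the name of the read-out) and lower numbers for less inhibition), compound 1 gives 25.1%
compound 2, `CCCCCCCCCCCCCC[C@H](O)[C@H](CN(C(C)C)C(C)C)NC(=O)OC(C)(C)C` — in this assay compound 2 gives 11.3%

Compound 2 stands lowest of the two numbers in this assay; its nearest neighbour is compound 1, whose number lies higher by an amount beyond the usual scatter. Among the compounds with values here, no step between the two measured compounds is computed, as they differ in more than one place, so their two values are taken only as they stand.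

The next compound, compound 3, `CCCCCCCCCCCCCC[C@H](O)[C@H](CN(CCCC)CCCC)NC(=O)OC(C)(C)C`, is not yet measured. Against compound 2 the change is dibutylamino in place of diisopropylamino on a saturated chain carbon, two bonds along the chain from an amide-type nitrogen. Compound 1 carries the same dibutylamino group, together with a further change at the hydroxyl, and sits above compound 2 in this assay.

On these two numbers alone the step in this assay from compound 2 to compound 3 is expected to be small and upward, possibly no larger than the scatter: a number 7.7 percentage points higher from compound 2 to compound 3 (within the scatter). For compound 3 the estimated inhibition in this assay is 19%, with a range from 6% to 33%.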

Compound 3, a percentage reported as inhibition, at one concentration (the size of the read-out at that concentration, not a potency): 9.4%
The estimate for compound 3 lay 9.6 percentage points above the measured number; measured number inside the range.
By their numbers in this assay, from the lowest: compounds 3 and 2 (each within the scatter of the next); then compound 1.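

In this assay, dibutylamino in place of diisopropylamino on a saturated chain carbon, two bonds along the chain from an amide-type nitrogen, gives a number 1.9 percentage points lower from compound 2 to compound 3 (within the scatter) and so does not separate the two amino groups at this place while the hydroxyl is free. The oxygen is the place that now shows a real difference: hydrogen in place of methoxymethyl on an oxygen on a saturated carbon gives a number 15.7 percentage points lower from compound 1 to compound 3 (beyond the scatter) with dibutylamino held constant, which ties the higher number to the methoxymethyl group and not to the amine exchange. No measurement at hand offers a reason for either step.

Open, on these data alone, is whether a cyclic amine such as piperidine or morpholine, or a smaller one such as dimethylamino, would also leave the number unmoved at this place, and whether the diisopropylamino group would show the same step once the oxygen carries methoxymethyl. Also open, as far as these compounds go, is whether a simple methyl ether or an acetate on that oxygen would behave like methoxymethyl, and whether a shorter chain would alter either step.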